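The source may hold more compounds than are shown below. What is called first, only, known or untested is meant among the compounds shown, and "the series" means these compounds.

Measured compounds:
Compound 1 `O=C(Nc1cccc(CNc2nccnc2Cl)c1)NC1CCCCC1`: in a functional assay on T-24 cells (Homo sapiens) for antiproliferative activity, read by MTT assay, with a stated time of 48 h (on this read-out lower numbers stand for stronger inhibition and higher numbers for weaker inhibition), compound 1 reaches only the limit > 40000 nM.
Compound 2 `CCc1ccc(NC(=O)Nc2cccc(CNc3nccnc3Cl)c2)c(CC)c1`: compound 2 gives 6390 nM in this assay.
Compound 3 `O=C(Nc1ccc(C(F)(F)F)cc1)Nc1cccc(CNc2nccnc2Cl)c1`: compound 3 gives 4580 nM in this assay.

Compound 1 thus stands at the limit of > 40000 nM in this assay, at which 1 of the 3 values shown sits, with no number of its own, while compounds 2 and 3 are the two with numbers. Compound 4 `O=C(Nc1cccc(Cl)c1)Nc1cccc(CNc2nccnc2Cl)c1` is not yet measured. It differs from compound 1 in one place: 3-chlorophenyl in place of cyclohexyl on an amide-type nitrogen. The change puts an aromatic ring on the amide-type nitrogen, as compounds 2 and 3 carry. Going by the values given here, no measured step between a cyclohexyl and an aromatic ring exists here; from the values of compounds 2 and 3 the step in this assay is expected to be a clear move toward stronger inhibition, beyond the scatter. Compound 4 is expected at 5000 nM (range 1500 nM to 20000 nM). That estimate would mean a step of an at least 8.0-fold lower number from compound 1 to compound 4 (0.90 log units; beyond the scatter).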

Compound 4, half-maximal inhibitory concentration: 6810 nM
For compound 4 the middle estimate is 1.4-fold (0.13 log units) below the measured one; measured number inside the range.
By their numbers in this assay, from the lowest: compounds 3, 2 and 4 (each within the scatter of the next). At a limit, above all of these: compound 1.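

Going by these compounds alone, on the amide-type nitrogen, 3-chlorophenyl in place of cyclohexyl gives the only single-place comparison at this position in this assay: an at least 5.8-fold lower number from compound 1 to compound 4 (0.76 log units; beyond the scatter). Compound 1 stands at a limit, so the size of this step is only a lower bound: the limit of > 40000 nM in this assay, at which 1 of the 4 values shown sits. This pair alone does not separate the aromatic ring from the chlorine as the source of the step.

Open, on these data alone, is what an unsubstituted phenyl, a pyridyl ring or a benzyl group on this nitrogen would give. Also open, as far as these compounds go, is whether a cyclohexyl bearing chlorine would differ from compound 1.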